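The compounds below may be only part of what the source reports. "The series", "measured", "known", "first", "only" and "open" are said of these compounds alone.

The study measured two compounds in an ADME assay on WI-38 cells (Homo sapiens) for cytotoxicity, read by colorimetric assay and crystal violet staining, with a stated time of 24 h (a lower number here means a stronger inhibitor, a higher number a weaker inhibitor), and leaves a third to be measured. Compound 1, `COc1ccc(OC)c(/C=N/NC(=O)c2ccc(-c3cccc(Cl)c3)nc2C)c1`, and compound 2, `COc1ccc(/C=N/NC(=O)c2ccc(-c3cccc(Cl)c3)nc2C)cc1OC`, share the same core and differ in how the two methoxy groups sit on the outer ring. In this assay compound 1 gives 188 ug/mL, and compound 2 gives 168 ug/mL. Compound 1 holds the higher of the two numbers, but the gap to compound 2 lies within the scatter, so nothing can be said about an order between them.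

Compound 3, `COc1ccc(OC)c(/C=N/NC(=O)c2ccc(-c3ccc(Cl)cc3)nc2C)c1`, keeps the methoxy pattern of compound 1 and changes only the chlorinated ring: 4-chlorophenyl in place of 3-chlorophenyl on an aromatic carbon. The two compounds have the same atoms joined differently. Among the measured compounds shown here, no step between measured compounds shows what moving the chlorine does here, so the expectation rests on the closeness of compound 1 and compound 2 alone. The step of a 1.1-fold lower number from compound 1 to compound 3 (0.03 log units; within the scatter) is expected to stay within the scatter, with no clear direction. Compound 3 is therefore estimated at 175 ug/mL, with a range from 90 ug/mL to 330 ug/mL.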

Compound 3, half-maximal inhibitory concentration: 500 ug/mL
The estimate for compound 3 lay 2.9-fold (0.46 log units) below the measured number; measured number outside the range, above it.
By their numbers in this assay, from the lowest: compounds 2 and 1 (each within the scatter of the next); then compound 3.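

In this assay the exchange of 3-chlorophenyl for 4-chlorophenyl gives a 2.7-fold higher number from compound 1 to compound 3 (0.42 log units; beyond the scatter) and so shows that this position on the shared core responds to where the chlorine sits on the outer ring, even though the two compounds have the same atoms. Compound 1 and compound 2, which differ only in how the two methoxy groups sit, had stayed within the scatter of each other and gave no such separation. The step is modest and rests on this single pair, but it points towards a weaker inhibitor in this assay with 4-chlorophenyl, at least with the methoxy pattern of compound 1. Nothing shown here accounts for the shift.

The compounds shown leave open whether the same move of the chlorine would give a step of similar size with the methoxy pattern of compound 2. They also leave open how this position would respond if the chlorine gave way to another group, such as an amine or a carboxylic acid.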